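Methyl on the cyanoguanidine nitrogen of the histamine chain

A few compounds are considered here, and "the series" means these few. Any claim that something is new, unique, unknown or untested is made for them only; others in the source may bear on it.

Measured compounds in an in vitro functional assay on Sf9 cells for antagonist activity at histamine H2 receptor (Homo sapiens); a lower number here means a less potent compound, a higher number a more potent compound, by a factor of ten per unit of this negative logarithm:
Compound 1 `N#C/N=C(/NCCCCc1c[nH]cn1)NCCCC1CCCCC1` gives < 5, a limit of the assay.
Compound 2 `N#C/N=C(/NCCCCc1c[nH]cn1)NCCCc1ccncc1` gives 5.11.
Compound 3 `N#C/N=C(\N)NCCCCc1c[nH]cn1` gives < 5, a limit of the assay.

Compound 3 stands at the limit of this assay; no number is available for it, only that the assay reported nothing above its floor. Compound 4 `CN/C(=N\C#N)NCCCCc1c[nH]cn1` differs from it only in methyl in place of hydrogen on an amine nitrogen: amino to methylamino, the hydrogen leaving and a single carbon entering on the nitrogen attached to the carbon with a double bond to nitrogen.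

For the measured compounds named here, the one measured step, a number at least 0.11 log units higher from compound 1 to compound 2 (that floor lies within the scatter), also changes what sits on that same nitrogen, and its floor lies within the scatter. Two of the three values shown, including that of compound 3, sit at the limit of < 5 in this assay, at which 2 of the 3 values shown sit. The measured compounds therefore give no sign that a substituent on this nitrogen moves this assay far; the step from compound 3 to compound 4 is expected to be a step that the limit leaves unreadable from compound 3 to compound 4, small and possibly hidden under the limit. Compound 4 is estimated at 4.9, between 4.3 and 5.5.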

Compound 4, negative logarithm of the antagonist equilibrium constant: < 5
Compound 4: no number, only a limit; the forecaster's own chance of this, stated with the estimate: 55%; the middle value lies beyond the limit too.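

In this assay compound 4 gives < 5, a limit of the assay, so methyl on this amine nitrogen does not bring the compound to a readable value. The steps linking compound 4 to compound 3 and to compound 1 cannot be read, as a limit stands at each end of them. The one readable step, hydrogen in place of 2-(pyridin-4-yl)ethyl, is a number at least 0.11 log units lower from compound 2 to compound 4 (that floor lies within the scatter), so the series gains only a floor for that side chain, and most of it now rests at one limit: the limit of < 5 in this assay, at which 3 of the 4 values shown sit.

On these data alone, whether methyl differs from hydrogen on this nitrogen at all remains open. Also open, as far as these compounds go, is whether a longer chain ending in an amine or a carboxylic acid at this nitrogen would give a value clearly above the limit.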